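Fluoro to hydroxy: a step expected to stay small

A few compounds are considered here, and "the series" means these few. Any claim that something is new, unique, unknown or untested is made for them only; others in the source may bear on it.

In a functional assay on SGC-7901 cells (Homo sapiens) for antiproliferative activity, read by MTT assay, with a stated time of 48 h (a lower number here means a stronger inhibitor, a higher number a weaker inhibitor), compound 1 (`COc1ccc(-c2nnc(SCc3ccc(Cl)nc3)o2)cc1`) gives 3.5 ug/mL and compound 2 (`Fc1ccc(-c2nnc(SCc3ccc(Cl)nc3)o2)cc1`) gives 3.67 ug/mL so the two stand within the scatter of each other. Compound 3 (`Oc1ccc(-c2nnc(SCc3ccc(Cl)nc3)o2)cc1`) differs from compound 2 by hydroxy in place of fluoro on an aromatic carbon, para to a large group (hydroxy in place of fluoro on an aromatic carbon). Among the measured compounds shown here, only one measured step bears on this change, fluoro in place of methoxy on an aromatic carbon, and it is small. Hydroxy itself has not yet been measured at this carbon, so the evidence is slim. Resting on a 1.0-fold higher number from compound 1 to compound 2 (0.02 log units; within the scatter) as the only guide, no step beyond the scatter is expected in this assay in either direction. The expected step is a 1.0-fold lower number from compound 2 to compound 3 (0.01 log units; within the scatter) as an estimate only. For compound 3 the estimate is 3.6 ug/mL with an expected range from 1.8 ug/mL to 7.5 ug/mL as its two ends.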

Compound 3, half-maximal inhibitory concentration: > 20 ug/mL
Compound 3 was reported as a limit (the forecaster's own chance of this, stated with the estimate: 2%); at least 5.5-fold (0.74 log units) between middle value and limit.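

In this assay the change from 4-fluorophenyl to 4-hydroxyphenyl is not a silent one, with an at least 5.4-fold higher number from compound 2 to compound 3 (0.73 log units; beyond the scatter) while the swap of fluoro for methoxy on the same carbon had stayed within the scatter. Taking only the methyl off the oxygen gives an at least 5.7-fold higher number from compound 1 to compound 3 (0.75 log units; beyond the scatter) and so, at this carbon, fluoro and methoxy stand level while hydroxy stands apart. For compound 3 the reading of > 20 ug/mL is a limit and not a number, so both steps give only a minimum size.

Going by these compounds, how far compound 3 truly lies from the other two stays open. So does whether an amine or a carboxylic acid on this carbon would follow hydroxy or would stand with fluoro and methoxy.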